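A few compounds are considered here, and "the series" means these few. Any claim that something is new, unique, unknown or untested is made for them only; others in the source may bear on it.

Two enones on a shared core have been measured so far. Compound 1 `COc1cc(-c2cc(/C=C/C(=O)c3ccc(N)cc3)[nH]n2)cc(OC)c1OC` gives 28900 nM in a functional assay on SK-OV-3 cells (Homo sapiens) for inhibition, read by sulforhodamine B assay, with a stated time of 48 h; on this read-out higher numbers stand for lower toxicity in this test and lower numbers for higher toxicity in this test. Compound 2 `COc1ccc(C(=O)/C=C/c2cc(-c3cc(OC)c(OC)c(OC)c3)n[nH]2)cc1OC` gives 27600 nM in this assay; the step of a 1.0-fold lower number from compound 1 to compound 2 (0.02 log units; within the scatter) lies within the scatter, so compound 2 stands level with compound 1 on these two numbers. Compound 3 `COc1ccc(C(=O)/C=C/c2cc(-c3cc(OC)c(OC)c(OC)c3)n[nH]2)cc1` differs from compound 2 by hydrogen in place of methoxy on an aromatic carbon. Within the data shown here, no measured step removes a methoxy from this ring; the only step in hand, a 1.0-fold lower number from compound 1 to compound 2 (0.02 log units; within the scatter), exchanged the whole aryl group without moving the number, so nothing beyond the scatter is expected here. For compound 3 the estimate is 30000 nM, range 12000 nM to 75000 nM, an expected step of a 1.1-fold higher number from compound 2 to compound 3 (0.04 log units; within the scatter).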

Compound 3, concentration lethal to 50% of the cells: > 100000 nM
Compound 3: only a limit was reported; the forecaster's own chance of this, stated with the estimate: 5%; middle value at least 3.3-fold (0.52 log units) away from the limit.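

In this assay compound 3 carries a limit and not a number: the limit of > 100000 nM in this assay, at which 1 of the 3 values shown sits.
Hydrogen in place of methoxy, turning 3,4-dimethoxyphenyl into 4-methoxyphenyl, gives an at least 3.6-fold higher number from compound 2 to compound 3 (0.55 log units; beyond the scatter) and so shows that this single position can move the number, where the exchange of the whole aryl group did not. Methoxy in place of amino gives an at least 3.4-fold higher number from compound 1 to compound 3 (0.53 log units; beyond the scatter) and so sets 4-methoxyphenyl apart from both 4-aminophenyl and 3,4-dimethoxyphenyl.

Going by these compounds, the full size of both steps stays open, since one end of each is a limit. Also open, on these data alone, is whether a hydroxy group or a chlorine atom in place of the remaining methoxy would keep the number at this limit.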